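Replacing the oxadiazole side chain in the aminopyrazolopyrimidine series

The source may hold more compounds than are shown below. What is called first, only, known or untested is meant among the compounds shown, and "the series" means these compounds.

Among the compounds with values here, compound 2 `CCCNCc1nc(Nc2nc(C)nc3c2c(C)nn3-c2ccc(OC)cc2C)no1` gives 124 nM in a functional assay on CHO cells for antagonist activity at corticotropin-releasing factor receptor 1 (Homo sapiens), read by cAMP accumulation (on this read-out higher numbers stand for weaker inhibition and lower numbers for stronger inhibition), the highest of the two numbers so far; compound 1 `CCCNCc1noc(Nc2nc(C)nc3c2c(C)nn3-c2ccc(OC)cc2C)n1` gives 84 nM, and the two lie within the scatter of each other, as a 1.5-fold higher number from compound 1 to compound 2 (0.17 log units; within the scatter) shows. Compound 3 `CCC[C@H](CO)Nc1nc(C)nc2c1c(C)nn2-c1ccc(OC)cc1C` is not yet measured. It differs from compound 2 by 1-(hydroxymethyl)butyl in place of 5-((propylamino)methyl)-1,2,4-oxadiazol-3-yl on a nitrogen on an aromatic ring; the side chain loses its ring and most of its acceptors while keeping one donor. Within the data shown here, the only measured step, a 1.5-fold higher number from compound 1 to compound 2 (0.17 log units; within the scatter), exchanges one oxadiazole regioisomer for the other and does not bear on removing the ring altogether, so no measured step informs this change. The expectation is therefore set near the measured pair with a wide range: compound 3 is estimated at 80 nM, between 15 nM and 400 nM, which means an expected step of a 1.6-fold lower number from compound 2 to compound 3 (0.19 log units; within the scatter).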

Compound 3, inhibition constant: 76 nM
Compound 3: middle estimate off by 1.1-fold (0.02 log units), on the high side; the range from low to high includes it.
By their numbers in this assay, from the lowest: compounds 3, 1 and 2 (each within the scatter of the next).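

In this assay, the 1-(hydroxymethyl)butyl side chain on a nitrogen on an aromatic ring cannot be separated from either oxadiazole side chain, with a 1.6-fold lower number from compound 2 to compound 3 (0.21 log units; within the scatter) and a 1.1-fold lower number from compound 1 to compound 3 (0.04 log units; within the scatter). At this position, therefore, a side chain with no ring and fewer heavy atoms reads level with both side chains that carry the five-membered aromatic ring and the propylamino group, so neither feature is needed to hold this level within these three compounds. Nothing at hand accounts for this equivalence.

Still open, on these data alone, is whether the opposite configuration at the defined stereocentre of 1-(hydroxymethyl)butyl reads the same, and whether an amine in place of the hydroxyl group, or a longer chain, holds this level. A single open-chain compound sets no trend among open-chain side chains.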